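Alkynyluracils bearing a phthalimide-linked butenyl chain

The source may hold more compounds than are shown below. What is called first, only, known or untested is meant among the compounds shown, and "the series" means these compounds.

Measured compounds:
compound 1, `Cc1ccc(C#Cc2cn(C/C=C\CN3C(=O)c4ccccc4C3=O)c(=O)[nH]c2=O)cc1` — > 100000 nM
compound 2, `CCCCc1ccc(C#Cc2cn(C/C=C/CN3C(=O)c4ccccc4C3=O)c(=O)[nH]c2=O)cc1` — 79000 nM

Going by the values given here, in a functional assay on MIA PaCa-2 cells (Homo sapiens) for antiproliferative activity, read by MTT assay, with a stated time of 3 days (on this read-out higher numbers stand for weaker inhibition and lower numbers for stronger inhibition), compound 2 gives 79000 nM, the only numerical value in the set. Compound 1 returns only a limit, (the limit of > 100000 nM in this assay, at which 1 of the 2 values shown sits), and no number. Among the compounds with values here, compound 1 and compound 2 differ in two places, so the pair yields no single step, and the two values show only that one sits at the limit while the other lies beneath it.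

Compound 3, `CCCCc1ccc(C#Cc2cn(C/C=C\CN3C(=O)c4ccccc4C3=O)c(=O)[nH]c2=O)cc1`, is not yet measured. Its relation to compound 2 is the two compounds have the same atoms and bonds and differ only in configuration as drawn: 1 of 1 stereo elements differ; a double bond is drawn E in compound 2 and Z in compound 3. Within the data shown here, with no measured step for a change of this kind, the size of the effect in this assay is open; a step of up to the usual scatter in either direction is possible, and compound 1, which carries the Z-drawn bond and sits at the limit, leaves room for a shift toward weaker inhibition. Compound 3 is expected near 100000 nM, within 40000 nM to 250000 nM. The expected step is a 1.3-fold higher number from compound 2 to compound 3 (0.10 log units; within the scatter), toward weaker inhibition, with a fair chance that only a limit is reported.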

Compound 3, half-maximal inhibitory concentration: 56000 nM
Compound 3: middle estimate off by 1.8-fold (0.25 log units), on the high side; the measured number falls inside the stated range.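

In this assay, going by these compounds alone, the first step on the double bond of the butenyl chain is a 1.4-fold lower number from compound 2 to compound 3 (0.15 log units; within the scatter), so the E and Z drawings of this bond are not told apart on this read-out, and the pair isolates that single change: the fact that compounds 2 and 3 differ only in the configuration as drawn. Compound 1, which shares the Z-drawn bond with compound 3, gives a limit and not a number: the limit of > 100000 nM in this assay, at which 1 of the 3 values shown sits. The step for propyl in place of hydrogen on a saturated chain carbon bound to an aromatic carbon can now be read only as a floor, an at least 1.7-fold lower number from compound 1 to compound 3 (0.25 log units; that floor lies within the scatter), which leaves the size of the effect of this change undetermined and does not separate it from the scatter.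

The compounds shown vary only in the alkyl group and the double-bond configuration, with the phthalimide unchanged throughout, so it remains open whether any change to the series moves the number beyond the scatter. A hexyl chain in place of the butyl chain, or a primary amine in place of the phthalimide, would address the two ends of the molecule separately.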